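Aryl swap on the ring nitrogen: compound 3 to compound 4

The source may hold more compounds than are shown below. What is called first, only, known or untested is meant among the compounds shown, and "the series" means these compounds.

In an ADME assay on GES1 cells (Homo sapiens) for cytotoxicity, read by MTT assay, with a stated time of 24 h (a higher number here means that more compound is tolerated, a lower number that less compound is tolerated), compound 3 `Cc1cccc(-n2cc(-c3cccc(NS(=O)(=O)c4c[nH]c(=O)[nH]c4=O)c3)nn2)c1` gives 18500 nM. Compound 1 `Cc1ccccc1-n1cc(-c2ccccc2NS(=O)(=O)c2c[nH]c(=O)[nH]c2=O)nn1` gives 19900 nM and compound 2 `O=c1[nH]cc(S(=O)(=O)Nc2cccc(-c3cn(-c4ccccc4)nn3)c2)c(=O)[nH]1` gives 22500 nM; all three numbers lie within the scatter of one another, so compound 3 cannot be set apart from either. Among the compounds with values here, the only single-point step, a 1.2-fold lower number from compound 2 to compound 3 (0.09 log units; within the scatter), also stays within the scatter. Compound 4 `O=c1[nH]cc(S(=O)(=O)Nc2cccc(-c3cn(-c4ccccc4F)nn3)c2)c(=O)[nH]1` differs from compound 3 by 2-fluorophenyl in place of 3-methylphenyl on an aromatic nitrogen. Within the data shown here, no measured step exchanges one aryl group for another on that ring nitrogen, so nothing bears on this change directly; the one step available, methyl in place of hydrogen on an aromatic carbon, moved nothing beyond the scatter. Compound 4 is therefore expected to show no step beyond the scatter, a 1.0-fold higher number from compound 3 to compound 4 (0.01 log units; within the scatter). The estimate for compound 4 is 19000 nM, with a range from 9000 nM to 40000 nM.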

Compound 4, half-maximal cytotoxic concentration: "not toxic" (no number reported)
No number was reported for compound 4, so the estimate cannot be set against anything.
By their numbers in this assay, from the lowest: compounds 3, 1 and 2 (each within the scatter of the next).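

Within the data shown here, compound 4 is recorded as "not toxic" without a number, so no step from compound 3 to compound 4 can be read. The compounds shown leave open how 2-fluorophenyl and 3-methylphenyl compare on the ring nitrogen. Nothing available bears on this result.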